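Selenium for sulfur on the imine carbon of compound 1

This account rests on a few compounds, and the source may have more. Where it says the series, first, only, none or still open, it means among the compounds named here.

Three compounds have numbers in an ADME assay on MCF-10A cells (Homo sapiens) for cytotoxicity, read by MTT assay, with a stated time of 72 h; on this read-out lower numbers stand for stronger inhibition of growth and higher numbers for weaker inhibition of growth. Compound 1 `CS/C(=N\C(=O)c1csc([N+](=O)[O-])c1)NC(=O)c1csc([N+](=O)[O-])c1` gives 1550 nM, the second highest of the three. Compound 3 `C[Se]/C(=N\C(=O)c1cc(-c2ccccc2)nc2ccccc12)NC(=O)c1cc(-c2ccccc2)nc2ccccc12` gives 710 nM, a lower number beyond the scatter, while compound 2 `CS/C(=N\C(=O)c1cccs1)NC(=O)c1cccs1` gives 19700 nM, the highest number by a wide margin. Compound 4 `C[Se]/C(=N\C(=O)c1csc([N+](=O)[O-])c1)NC(=O)c1csc([N+](=O)[O-])c1` has no number yet in this assay; it differs from compound 1 by a group of 2 heavy atoms (1 carbon, 1 selenium; no ring) in place of a group of 2 heavy atoms (1 carbon, 1 sulfur; no ring), on a carbon with a double bond to nitrogen. For the measured compounds named here, no measured pair shows this exchange alone, and compound 3 carries its selenium group on a different core. A modest step toward a lower number is expected, a 1.6-fold lower number from compound 1 to compound 4 (0.19 log units; within the scatter). Compound 4 is estimated at 1000 nM, between 400 nM and 3000 nM.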

Compound 4, concentration for 50% growth inhibition: 1950 nM
The estimate for compound 4 lay 2.0-fold (0.29 log units) below the measured number; the measured number falls inside the stated range.
By their numbers in this assay, from the lowest: compound 3; then compounds 1 and 4 (each within the scatter of the next); then compound 2.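

For the compounds shown here, on the core of compound 1, the only matched exchange at this carbon with a double bond to nitrogen, the selenium group in place of methylsulfanyl, gives a 1.3-fold higher number from compound 1 to compound 4 (0.10 log units; within the scatter) in this assay. On this core, the read-out therefore does not separate the two groups. No available evidence bears on why this is so.

The compounds shown leave open whether the same exchange reads alike on other cores, and what an amine or a longer chain on this carbon would give.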